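Trifluoromethyl on the Benzyl Ring in Two Related Cores

The compounds below may be only part of what the source reports. "The series", "measured", "known", "first", "only" and "open" are said of these compounds alone.

Compound 1, `Cc1ccc(-n2cc(-c3ccc(CN4CCN(C)CC4)cc3)nn2)cc1Nc1nccc(-c2cccnc2)n1`: 790 nM
Compound 2, `Cc1ccc(-n2cc(-c3ccc(CN4CCN(C)CC4)c(C(F)(F)F)c3)nn2)cc1Nc1nccc(-c2cccnc2)n1`: 40 nM
Compound 3, `Cc1ccc(-c2nnc(-c3ccc(CN4CCN(C)CC4)cc3)o2)cc1Nc1nccc(-c2cccnc2)n1`: 4900 nM

Of the compounds shown here, three have been measured in a functional assay on K562 cells (Homo sapiens) for inhibition, read by MTT assay, with a stated time of 72 h; a higher number here means a weaker inhibitor, a lower number a stronger inhibitor. Compound 1 gives 790 nM, and compound 2, which carries trifluoromethyl in place of hydrogen on an aromatic carbon, gives 40 nM; that single change made a 20-fold lower number from compound 1 to compound 2 (1.30 log units; beyond the scatter). Compound 3 has a different core; the difference between the two cores is not broken down here. In this assay compound 3 gives 4900 nM, the highest of the three numbers.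

Compound 4, `Cc1ccc(-c2nnc(-c3ccc(CN4CCN(C)CC4)c(C(F)(F)F)c3)o2)cc1Nc1nccc(-c2cccnc2)n1`, has not been measured. It differs from compound 3 by trifluoromethyl in place of hydrogen on an aromatic carbon, the same change as from compound 1 to compound 2, at the same place. For the measured compounds named here, because the earlier change made a 20-fold lower number from compound 1 to compound 2 (1.30 log units; beyond the scatter), a step of similar direction is expected from compound 3 to compound 4, though its size rests on only one prior example: the expected step is a 14-fold lower number from compound 3 to compound 4 (1.15 log units; beyond the scatter). On that basis compound 4 is estimated at 350 nM in this assay, with a likely range from 100 nM to 1500 nM.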

Compound 4, half-maximal inhibitory concentration: 510 nM
Beside the measured number, compound 4's estimate is 1.5-fold (0.16 log units) below it; the range from low to high includes it.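

Trifluoromethyl in place of hydrogen carries over to the second core in direction: in this assay it gives a 9.6-fold lower number from compound 3 to compound 4 (0.98 log units; beyond the scatter), so the number falls on both cores. Set side by side, the two steps are no further apart than repeated measurements of this kind can be, so they can be read as one effect of similar size: the same change on two cores in this assay, a 20-fold lower number (1.30 log units; beyond the scatter) from compound 1 to compound 2 and a 9.6-fold lower number (0.98 log units; beyond the scatter) from compound 3 to compound 4, 2.1-fold (0.31 log units) apart, within the scatter of two such steps. This shows that the change transferred between these two cores in this cell assay, but two cores are a small sample, so it does not show that the step would hold on any other core, and the numbers alone do not say why it occurs.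

The compounds shown leave open whether a methyl group, a chlorine atom or a nitrile in the same place would lower the number as trifluoromethyl does. They also leave open whether the step survives when the (4-methylpiperazin-1-yl)methyl group gives way to another amine, such as morpholine.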